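Cytotoxicity notes on the chain-varied series

The source may report more compounds than this note shows. Statements on the series, on what has been measured and on what is new or still open speak of the compounds shown alone.

Measured in a functional assay on HEL cells (Homo sapiens) for cytotoxicity; on this read-out lower numbers stand for higher toxicity in this test and higher numbers for lower toxicity in this test (both values are limits):
- compound 1 `CCCCCc1cc2cn([C@H]3C[C@H](O)[C@@H](CO)O3)c(=O)nc2o1` gives > 50000 nM as a limit
- compound 2 `CCCCCCCCc1cc2cn([C@H]3C[C@H](O)[C@@H](CO)O3)c(=O)nc2o1` gives > 50000 nM as a limit

Compound 2 thus stands only at a limit, with no number. Compound 3 `C=CCCCc1cc2cn([C@H]3C[C@H](O)[C@@H](CO)O3)c(=O)nc2o1` carries vinyl in place of pentyl on a saturated chain carbon, three bonds along the chain from an aromatic carbon. Among the compounds with values here, the one measured step bearing on this (a step that the two limits leave unreadable from compound 1 to compound 2) has no readable size, and both measured compounds sit at the same limit (the limit of > 50000 nM in this assay, at which 2 of the 2 values shown sit). In this assay no direction can be expected, and the expected step (a number no higher from compound 2 to compound 3 (the limit leaves the size open)) is none beyond the scatter. Compound 3 is estimated at 50000 nM with an expected range of 20000 nM to 100000 nM and will probably be reported as a limit again.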

Compound 3, half-maximal cytotoxic concentration: > 200000 nM
Compound 3 gave a limit, no number (the forecaster's own chance of this, stated with the estimate: 85%); at least 4.0-fold (0.60 log units) between middle value and limit.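

In this assay, within the data shown here, compound 1, compound 2 and compound 3 all stand at limits, so no step among them can be read. The compounds shown leave open whether chain changes affect toxicity in this test at all.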